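Anilide Swap on a Shared Core: Methyl to Nitro

A few compounds are considered here, and "the series" means these few. Any claim that something is new, unique, unknown or untested is made for them only; others in the source may bear on it.

Compound 1 `Cc1ccc(NC(=O)c2ccc(/N=N\c3c[nH]c4ccccc34)cc2)cc1`: 300 nM
Compound 2 `O=C(Nc1ccccc1Cl)c1ccc(/N=N\c2c[nH]c3ccccc23)cc1`: "not active" (no number reported)
Compound 3 `O=C(Nc1ccccc1F)c1ccc(/N=N\c2c[nH]c3ccccc23)cc1`: 106000 nM

Of the compounds shown here, three built on the shared core have been tested in a functional assay on P388 cells (Mus musculus) for inhibition, read by MTT assay, with a stated time of 72 h; on this read-out lower numbers stand for stronger inhibition and higher numbers for weaker inhibition. Compound 1 gives the lowest number among the values reported, with compound 3 as its nearest neighbour, and the step of a 350-fold higher number from compound 1 to compound 3 (2.55 log units; beyond the scatter) is large. Compound 2 gave no number in this assay and is reported only as "not active" (no number reported).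

Compound 4 `O=C(Nc1ccc([N+](=O)[O-])cc1)c1ccc(/N=N\c2c[nH]c3ccccc23)cc1` has not yet been measured. It differs from compound 1 in one place: nitro in place of methyl on an aromatic carbon. Put one bond further out, the difference reads 4-methylphenyl to 4-nitrophenyl.

Among the compounds with values here, the only measured step with a single number, from compound 1 to compound 3, exchanges both the group and its place on the ring, so it bears only loosely on the change to compound 4. Within the data shown here, no measured pair shows what a nitro group at this place does. Given that, a moderate loss is estimated for compound 4, a 5.0-fold higher number from compound 1 to compound 4 (0.70 log units; beyond the scatter), with a broad range because of the size of the step of a 350-fold higher number from compound 1 to compound 3 (2.55 log units; beyond the scatter) seen when the anilide was altered. Compound 4 is therefore expected to give about 1500 nM, between 200 nM and 30000 nM.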

Compound 4, half-maximal inhibitory concentration: 11200 nM
For compound 4 the middle estimate is 7.5-fold (0.87 log units) below the measured one; the range from low to high includes it.
By their numbers in this assay, from the lowest: compound 1; then compound 4; then compound 3.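

In this assay, the exchange of 4-methylphenyl for 4-nitrophenyl keeps the substituent at the same place on the ring, para to a large group, and thus isolates a change of group alone: a 37-fold higher number from compound 1 to compound 4 (1.57 log units; beyond the scatter) is a large rise, so this place does not accept methyl and nitro equally. The anilide can still shift the number in the other direction, since a 9.5-fold lower number from compound 3 to compound 4 (0.98 log units; beyond the scatter) is a modest fall, leaving the 4-nitrophenyl anilide of compound 4 in the middle of the three numbered compounds, with the 4-methylphenyl anilide of compound 1 still the lowest. Nothing measured here accounts for the difference between methyl and nitro at this place.

From the compounds shown here alone, with only methyl and nitro compared at this carbon, it remains open how an amine, a carboxylic acid, a methoxy group or a longer alkyl chain would behave there. Going by these compounds, it is also open how much of the large rise in compound 3 belongs to fluorine itself and how much to its place on the ring, which a 4-fluorophenyl anilide would help to separate.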